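Thioether series: replacing dimethylamino with methyl

The source may hold more compounds than are shown below. What is called first, only, known or untested is meant among the compounds shown, and "the series" means these compounds.

- compound 1 `CN(C)c1ncnc2[nH]cc(Sc3cccs3)c12`: 35300 nM
- compound 2 `CNc1ncnc2[nH]cc(Sc3cccs3)c12`: 26200 nM

In a functional assay on CEM-DNR cells (Homo sapiens), read by MTT assay, with a stated time of 3 days (on this read-out higher numbers stand for weaker inhibition and lower numbers for stronger inhibition), compound 1 gives 35300 nM. It has a single measured neighbour, and the comparison, a 1.3-fold lower number from compound 1 to compound 2 (0.13 log units; within the scatter), does not separate the two, so no order can be read between them.

Compound 3 `Cc1ncnc2[nH]cc(Sc3cccs3)c12` carries methyl in place of dimethylamino on an aromatic carbon. Among the compounds with values here, only one measured step bears on this change, and it alters the same group only in part, with hydrogen in place of methyl on the nitrogen. Within the data shown here, no measured compound lacks that nitrogen, so the evidence is indirect and the range is kept wide. Among the measured compounds shown here, with only that small step as a guide, the expected change is a 1.2-fold lower number from compound 1 to compound 3 (0.07 log units; within the scatter), which means no shift beyond the scatter is expected. For compound 3 the estimate is 30000 nM, with an expected range of 11000 nM to 80000 nM.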

Compound 3, half-maximal inhibitory concentration: > 50000 nM
Compound 3: no number, only a limit; the forecaster's own chance of this, stated with the estimate: 12%; middle value at least 1.6-fold (0.22 log units) from the limit.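

In this assay compound 3 gives only a limit, > 50000 nM, and not a number. Methyl on this aromatic carbon gives an at least 1.4-fold higher number from compound 1 to compound 3 (0.15 log units; that floor lies within the scatter) and an at least 1.9-fold higher number from compound 2 to compound 3 (0.28 log units; that floor lies within the scatter), so both steps are floors and their true size remains unknown. The earlier step changed only the substitution on the nitrogen, whereas this change removes the nitrogen from the position, and it is the first change in the series to give a limit rather than a number: the limit of > 50000 nM in this assay, at which 1 of the 3 values shown sits.

Going by these compounds, how far compound 3 lies past its limit stays open. Also open, on these data alone, is whether an unsubstituted amino group or a longer alkyl chain on the nitrogen at this position would give a measurable number.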